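Swapping fluoro for cyano on compound 2

This account rests on a few compounds, and the source may have more. Where it says the series, first, only, none or still open, it means among the compounds named here.

Compound 1 `O=C(Nc1ccccc1C(F)(F)F)c1cc(Cl)ccc1O`: 19000 nM
Compound 2 `O=C(Nc1ccc(F)cc1)c1cc(Cl)ccc1O`: 17000 nM

Both compounds were tested in an ADME assay on cells (Macrophage, Mus musculus) for cytotoxicity, read by resazurin assay, with a stated time of 3 days (on this read-out higher numbers stand for weaker inhibition and lower numbers for stronger inhibition), and their values lie within the usual scatter of each other, so compound 2 cannot be set apart from compound 1. Compound 3 `N#Cc1ccc(NC(=O)c2cc(Cl)ccc2O)cc1` has not been measured yet. It matches compound 2 except in one place: cyano in place of fluoro on an aromatic carbon (cyano in place of fluoro on an aromatic carbon, para to a large group). Within the data shown here, no measured step isolates a single change like this one. Among the measured compounds shown here, the only guide is that compound 1 at 19000 nM and compound 2 at 17000 nM show no gap beyond the scatter despite carrying different groups. In this assay no clear move in either direction is therefore expected. The expected step is a 1.1-fold lower number from compound 2 to compound 3 (0.05 log units; within the scatter) and no larger than the scatter allows. Compound 3 is estimated at 15000 nM with an expected range from 6000 nM to 38000 nM around that value.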

Compound 3, half-maximal inhibitory concentration: 11000 nM
For compound 3 the middle estimate is 1.4-fold (0.13 log units) above the measured one; the measured number falls inside the stated range.
By their numbers in this assay, from the lowest: compounds 3, 2 and 1 (each within the scatter of the next).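

Among these compounds, compound 2 and compound 3 form the first pair here that differs in one place only, so a single change on an aromatic carbon, para to a large group, can now be read on its own. In this assay putting cyano in place of fluoro gives a 1.5-fold lower number from compound 2 to compound 3 (0.19 log units; within the scatter) and so, although cyano counts as a hydrogen-bond acceptor and fluoro does not, the two compounds cannot be told apart. No measurement at hand explains this result.

One swap says little about this place as a whole: an amine, a carboxylic acid or a longer chain on the same aromatic carbon could still move the number beyond the scatter. On these data alone, whether cyano for fluoro would behave alike elsewhere on the ring also stays open.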